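A few compounds are considered here, and "the series" means these few. Any claim that something is new, unique, unknown or untested is made for them only; others in the source may bear on it.

Measured so far in an assay on a protein complex for inhibition of CDK8/Cyclin C (Homo sapiens), with a stated time of 1 h; a lower number here means a stronger inhibitor, a higher number a weaker inhibitor:
- compound 1, `CNC(=O)/C=C/c1ccncc1-c1ccc2cc[nH]c2c1`: 18.6 nM
- compound 2, `CCOC(=O)/C=C/c1ccncc1-c1ccc2cc[nH]c2c1`: 12.1 nM
- compound 3, `O=C(/C=C/c1ccncc1-c1ccc2cc[nH]c2c1)N1CCOCC1`: 43.9 nM

Compound 3 stands highest of the three in this assay; the steps of a 2.4-fold higher number from compound 1 to compound 3 (0.37 log units; beyond the scatter) and a 3.6-fold higher number from compound 2 to compound 3 (0.56 log units; beyond the scatter) both lie beyond the scatter, whereas a 1.5-fold lower number from compound 1 to compound 2 (0.19 log units; within the scatter) does not.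

Compound 4, `O=C(O)/C=C/c1ccncc1-c1ccc2cc[nH]c2c1`, is not yet measured. Its change from compound 3 is hydroxy in place of morpholin-4-yl on a carbonyl carbon. The two steps that bear on it are those that introduced the morpholin-4-yl group: a 2.4-fold higher number from compound 1 to compound 3 (0.37 log units; beyond the scatter) and a 3.6-fold higher number from compound 2 to compound 3 (0.56 log units; beyond the scatter), each a modest rise. Removing that group in favour of a single hydroxy is therefore expected to give a modest fall, though the wide range reflects that no acid has been measured in this series. Compound 4 is estimated at 30 nM, range 8 nM to 150 nM, that is an expected step of a 1.5-fold lower number from compound 3 to compound 4 (0.17 log units; within the scatter).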

Compound 4, half-maximal inhibitory concentration: 2.4 nM
The estimate for compound 4 lay 13-fold (1.10 log units) above the measured number; the whole stated range lies above it.
By their numbers in this assay, from the lowest: compound 4; then compounds 2 and 1 (each within the scatter of the next); then compound 3.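

In this assay the carboxy group gives the lowest number at this carbonyl carbon, with an 18-fold lower number from compound 3 to compound 4 (1.26 log units; beyond the scatter) and a 5.0-fold lower number from compound 2 to compound 4 (0.70 log units; beyond the scatter) and also a 7.8-fold lower number from compound 1 to compound 4 (0.89 log units; beyond the scatter) all beyond the scatter. The position therefore carries a wider span than the methylamino, ethoxy and morpholin-4-yl groups alone showed, and removing only the ethyl from the ester is enough to give a clear gain. No measurement at hand accounts for this gain.

On these data alone, whether a primary amide, a hydroxamic acid or a tetrazole can match the carboxy group remains open. So does the effect of a longer chain carrying the carboxy group.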